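Plasma stability notes: from compound 1 to compound 4

This account rests on a few compounds, and the source may have more. Where it says the series, first, only, none or still open, it means among the compounds named here.

The series shares one core bearing an aryl carboxylic acid, and in an ADME assay on a cell-free system (plasma, Rattus norvegicus) for metabolic stability, read by LC-MS, with a stated time of 1 h, at 37 degrees C, tested at 100 uM (on this read-out higher numbers stand for a more stable compound and lower numbers for a less stable compound), every measured member remains fully intact. Compound 1 `O=C(O)c1ccc(-c2cccc(COc3ccc4c(c3)CN(C3CCCC3)C4=O)c2)c(Cl)c1` gives 100% in this assay. Compound 2 `O=C(O)c1cc(-c2cccc(COc3ccc4c(=O)n(C5CC5)sc4c3)c2)ccc1Cl` gives 100%, and compound 3 `Cn1sc2cc(OCc3cccc(-c4ccc(Cl)c(C(=O)O)c4)c3)ccc2c1=O` gives 100%. The only documented step, no change at the digits printed from compound 2 to compound 3 (within the scatter), lies within the scatter, so compound 1 stands level with compounds 2 and 3 on the numbers shown; nothing among the three separates them, and all sit at the top of what the read-out can report.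

Compound 4 `COc1ccc(C(=O)O)cc1-c1cccc(COc2ccc3c(c2)CN(C2CCCC2)C3=O)c1` is the next member to be measured. Its difference from compound 1 is 5-carboxy-2-methoxyphenyl in place of 4-carboxy-2-chlorophenyl on an aromatic carbon. Among the compounds with values here, no measured step touches this part of the molecule: the step from compound 2 to compound 3 concerns a substituent on an aromatic nitrogen, not the pendant aryl acid, so it bears on the change only indirectly, as evidence that the series tolerates variation without loss. With every measured value at the ceiling and no step beyond the scatter anywhere, the step is expected to be no change at the digits printed from compound 1 to compound 4 (within the scatter), none beyond the scatter. Compound 4 is expected to give 100%, within a range of 90% to 100%.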

Compound 4, percent of the compound remaining: 100%
Estimate against measurement, compound 4: no gap at the digits printed; the range from low to high includes it.
By their numbers in this assay, from the lowest: compounds 1, 2, 3 and 4 (each within the scatter of the next).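

Working notes on the pendant aryl acid: in this assay, replacing 4-carboxy-2-chlorophenyl with 5-carboxy-2-methoxyphenyl gives no change at the digits printed from compound 1 to compound 4 (within the scatter), and this is the only step shown at this place, on an aromatic carbon, meta to a large group. The earlier step concerned a substituent on an aromatic nitrogen, so this reading extends the tolerated variation in the series from that nitrogen to the aryl acid itself. The two groups differ in both the carboxy numbering and the other substituent, with methoxy entering and chlorine leaving, so the result covers the change as a whole and cannot be divided between these features; nothing shown offers an explanation for it.

Going by these compounds, because all four compounds sit at the top of what the read-out can report, the margin of stability at this place remains open, as any loss would need a group that gives a lower reading. A methyl ester in place of the carboxylic acid, or an ethyl ester on the same ring, would test whether the series stays intact once a group of that kind is present.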